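The source may report more compounds than this note shows. Statements on the series, on what has been measured and on what is new or still open speak of the compounds shown alone.

Compound 1 `Cc1nnc(-c2nn(-c3ccccc3)c(-c3ccccc3)c2C#N)c2cn(-c3ccccc3)nc12`: 38400 nM
Compound 2 `N#Cc1c(-c2nnc(-c3nn(-c4ccccc4)c(-c4ccccc4)c3C#N)c3nn(-c4ccccc4)cc23)nn(-c2ccccc2)c1-c1ccccc1`: > 100000 nM

Both results come from a functional assay on MDA-N cells (Homo sapiens) for inhibition, read by sulforhodamine B assay, with a stated time of 48 h; on this read-out lower numbers stand for stronger inhibition of growth and higher numbers for weaker inhibition of growth. Compound 2 reads > 100000 nM, and this is a limit of this assay, not a number.

Compound 3 `N#Cc1c(-c2nnc(-c3nn(-c4ccccc4)c(-c4ccccc4)c3C#N)c3nn(-c4ccc(Cl)cc4)cc23)nn(-c2ccccc2)c1-c1ccccc1` is compound 2 with one phenyl changed to 4-chlorophenyl, so the chloro sits para to a large group: chloro in place of hydrogen on an aromatic carbon.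

Among the measured compounds shown here, no measured pair shows what this kind of change does in this assay, so the expectation is loose. A small move towards stronger inhibition of growth is expected, or none beyond the scatter, and the estimate for it reads an at least 1.4-fold lower number from compound 2 to compound 3 (0.15 log units; that floor lies within the scatter). The result may again be only a limit. The estimated value for compound 3 is 70000 nM, with an expected range of 30000 nM to 120000 nM.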

Compound 3, concentration for 50% growth inhibition: 2260 nM
Beside the measured number, compound 3's estimate is 31-fold (1.49 log units) above it; the whole stated range lies above it.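

In this assay, putting chloro in place of hydrogen on an aromatic carbon, which turns one phenyl into 4-chlorophenyl, gives an at least 44-fold lower number from compound 2 to compound 3 (1.64 log units; beyond the scatter). Among the compounds shown here, this is the first sign that this position matters: a change of a single heavy atom there moves growth inhibition well beyond the scatter. The full size of the step remains unknown because compound 2 gives only a limit of the assay, not a number: the limit of > 100000 nM in this assay, at which 1 of the 3 values shown sits.

Going by these compounds, it remains open whether chloro is special or whether another group at this position, such as fluoro, methoxy or an amine, would do the same. On these data alone, it is also open whether chloro would have a similar effect on one of the other phenyl rings.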